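Adding a second chloro to the aryl ring of compound 2

This account rests on a few compounds, and the source may have more. Where it says the series, first, only, none or still open, it means among the compounds named here.

Measured so far:
compound 1 `C=CCn1c(=O)/c(=C\c2ccc(F)c(Br)c2)[nH]c(=O)/c1=C\c1ccccc1OC`: "not active" (no number reported)
compound 2 `C=CCn1c(=O)/c(=C\c2cccc(Cl)c2)[nH]c(=O)/c1=C\c1ccccc1OC`: 5500 nM

Going by the values given here, in a functional assay on HeLa cells (Homo sapiens) for cytotoxicity, read by CCK-8 assay, with a stated time of 72 h (on this read-out higher numbers stand for weaker inhibition and lower numbers for stronger inhibition), compound 2 gives 5500 nM, the only number in this small set. Compound 1 is reported as "not active" (no number reported) in this assay, with no number. Compound 3 `C=CCn1c(=O)/c(=C\c2cccc(Cl)c2Cl)[nH]c(=O)/c1=C\c1ccccc1OC` differs from compound 2 by one change: chloro in place of hydrogen on an aromatic carbon. Among the compounds with values here, no measured pair shows what this change does, so the expectation rests on compound 2 alone. The step from compound 2 to compound 3 is expected to be small, a 1.2-fold lower number from compound 2 to compound 3 (0.09 log units; within the scatter), not clearly beyond the scatter in either direction. Compound 3 is therefore expected to give about 4500 nM, in a range from 1500 nM to 14000 nM.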

Compound 3, half-maximal inhibitory concentration: 1600 nM
Compound 3: the middle estimate sits 2.8-fold (0.45 log units) above what was measured; the range from low to high includes it.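

In this assay the change from 3-chlorophenyl to 2,3-dichlorophenyl gives a 3.4-fold lower number from compound 2 to compound 3 (0.54 log units; beyond the scatter) and so shows that this aromatic carbon, ortho to a chloro group, responds to a single added chloro. The earlier compounds shown here offered no pair that could show this. No measurement shown here explains why the number falls. As far as these compounds go, whether the lower number belongs to chloro itself, or would also come with a methyl group or an amine on this carbon, stays open. A single step also leaves open whether the same chloro would lower the number on another compound of this kind.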